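The source may report more compounds than this note shows. Statements on the series, on what has been measured and on what is new or still open speak of the compounds shown alone.

Compound 1 `CO[C@@H]1[C@@H](OC(=O)c2ccc(C)[nH]2)[C@@H](O)[C@H](Oc2ccc3c(N4CCNCC4)cc(=O)oc3c2C)OC1(C)C` carries an unsubstituted piperazin-1-yl group and, in a physicochemical assay for acid dissociation, compound 1 gives 8.3. Compound 2 `CO[C@@H]1[C@@H](OC(=O)c2ccc(C)[nH]2)[C@@H](O)[C@H](Oc2ccc3c(N4CC(C)NC(C)C4)cc(=O)oc3c2C)OC1(C)C` carries a 3,5-dimethylpiperazin-1-yl group instead, and compound 2 gives 8, with a number 0.30 log units lower from compound 1 to compound 2 (within the scatter). Compound 3 `CO[C@@H]1[C@@H](OC(=O)c2ccc(C)[nH]2)[C@@H](O)[C@H](Oc2ccc3c(N4CCN(C)CC4)cc(=O)oc3c2C)OC1(C)C` carries a 4-methylpiperazin-1-yl group; compound 3 gives 7.3, which is the lowest of the three numbers, with a number 1.00 log units lower from compound 1 to compound 3 (beyond the scatter) and a number 0.70 log units lower from compound 2 to compound 3 (beyond the scatter). Compound 4 `CO[C@@H]1[C@@H](OC(=O)c2ccc(C)[nH]2)[C@@H](O)[C@H](Oc2ccc3c(N4CCN(C)CC4)c(Cl)c(=O)oc3c2C)OC1(C)C` keeps the 4-methylpiperazin-1-yl group of compound 3 and differs from it only in this way: chloro in place of hydrogen on an aromatic carbon. None of the three measured steps touches this position; each of them changes the piperazine ring itself, and the two steps beyond the scatter both concern the amine nitrogen that carries the methyl in compound 3. Among the compounds with values here, there is therefore no measured step from which the size of the chloro step can be read, and the expectation for compound 4 is a step of a number 0.10 log units lower from compound 3 to compound 4 (within the scatter), not beyond the scatter. Compound 4 is estimated at 7.2, within 6.6 to 7.8.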

Compound 4, acid dissociation constant: 7.4
Compound 4: the middle estimate sits 0.20 log units below what was measured, within the range that was stated.
By their numbers in this assay, from the lowest: compounds 3 and 4 (each within the scatter of the next); then compounds 2 and 1 (each within the scatter of the next).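

In this assay, chloro in place of hydrogen on the aromatic carbon ortho to the 4-methylpiperazin-1-yl group gives a number 0.10 log units higher from compound 3 to compound 4 (within the scatter), the only step shown that falls outside the piperazine ring. The earlier compounds shown here said nothing about this position; now a single chlorine atom there, two atoms from the ring oxygen, is seen to leave the read-out within the scatter, whereas two of the three steps on the piperazine ring lay beyond it. Nothing measured here offers an explanation for this result.

The compounds shown leave open whether another group on this carbon, such as an amine, a nitrile or a carboxylic acid, would also stay within the scatter. They also leave open whether chloro would do so alongside the unsubstituted piperazin-1-yl group of compound 1.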